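A Pyrazolyl Replaces the Methylcarbamoyl on the Core

The source may hold more compounds than are shown below. What is called first, only, known or untested is meant among the compounds shown, and "the series" means these compounds.

Compound 3 `CNC(=O)c1cccc2c1CCC2c1ncc[nH]1` stands among three compounds that share one core, all tested in a functional assay on CHO cells for agonist activity at Alpha-1D adrenergic receptor (Homo sapiens), read by FLIPR and calcium flux; on this read-out higher numbers stand for an effect only at larger amounts of compound and lower numbers for an effect already at smaller amounts. In this assay compound 3 gives only a limit, > 10000 nM. Compound 1 `COc1cccc2c1CCC2c1ncc[nH]1` likewise gives only a limit in this assay, > 10000 nM. Compound 2 `c1ccc2c(c1)CCC2c1ncc[nH]1` too gives only a limit in this assay, > 10000 nM. Because all three sit at the limit of > 10000 nM in this assay, at which 3 of the 3 values shown sit, the steps a step that the two limits leave unreadable from compound 1 to compound 2, a step that the two limits leave unreadable from compound 1 to compound 3 and a step that the two limits leave unreadable from compound 2 to compound 3 stay unreadable in size. Compound 4 `c1cc(-c2cn[nH]c2)c2c(c1)C(c1ncc[nH]1)CC2` is not yet measured; it differs from compound 3 by 1H-pyrazol-4-yl in place of methylcarbamoyl on an aromatic carbon. Within the data shown here, no measured step bears readably on this change: every step among compounds 1, 2 and 3 is hidden by the limit. Nothing among them shows that any group at this carbon of the core brings an effect within the tested amounts. The step expected in this assay is a number no higher from compound 3 to compound 4 (the limit leaves the size open), most likely none beyond the scatter, with a further limit the probable outcome. Compound 4 is therefore estimated at 10000 nM in this assay, within 2000 nM to 30000 nM.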

Compound 4, half-maximal effective concentration: 319 nM
Compound 4: the middle estimate sits 31-fold (1.50 log units) above what was measured, outside the stated range (below it).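

With 1H-pyrazol-4-yl on this aromatic carbon of the shared core, this assay shows an at least 31-fold lower number from compound 3 to compound 4 (1.49 log units; beyond the scatter), along with an at least 31-fold lower number from compound 2 to compound 4 (1.49 log units; beyond the scatter) and an at least 31-fold lower number from compound 1 to compound 4 (1.49 log units; beyond the scatter). The group at this carbon can therefore bring an effect within the tested amounts, which hydrogen, methoxy and methylcarbamoyl did not show, and only compound 4 gives a number rather than a limit: the limit of > 10000 nM in this assay, at which 3 of the 4 values shown sit. Methylcarbamoyl and 1H-pyrazol-4-yl have the same counts of hydrogen-bond donors and acceptors, so equal counts do not go with an equal read-out here.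

From the compounds shown here alone, the steps among compounds 1, 2 and 3 cannot be read, and the true size of the three new steps stays open. The compounds shown also leave open whether a phenyl ring, an imidazolyl ring or a pyrazolyl ring bearing a methyl group on nitrogen would serve at this carbon.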